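Swapping bromine for chlorine on the side-chain phenyl ring

A few compounds are considered here, and "the series" means these few. Any claim that something is new, unique, unknown or untested is made for them only; others in the source may bear on it.

Of the compounds shown here, two sharing one core have been measured so far. Compound 1 `C#CCNC1CCc2c(SCCc3ccc(Cl)cc3)cccc21` carries a 4-chlorophenyl group on the saturated chain that runs from a sulfur, and compound 2 `C#CCNC1CCc2c(SCCc3cccc(Br)c3)cccc21` carries a 3-bromophenyl group in the same place. In an assay on isolated protein for inhibition of Amine oxidase [flavin-containing] B (Homo sapiens) (a lower number here means a stronger inhibitor, a higher number a weaker inhibitor), compound 1 gives 10800 nM, while compound 2 gives 30500 nM. The change a 2.8-fold higher number from compound 1 to compound 2 (0.45 log units; beyond the scatter) is a modest one, so compound 2 stands as the weaker of the two.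

Compound 3 `C#CCNC1CCc2c(SCCc3cccc(Cl)c3)cccc21` differs from compound 2 only by chloro in place of bromo on an aromatic carbon. Going by the values given here, no measured pair isolates this halogen swap: the single step from compound 1 to compound 2 changes both the halogen and the place it sits, so it bears on compound 3 only loosely. Exchanging one halogen for another of similar kind is expected to move the number little, if at all, beyond the scatter in this assay. Compound 3 is therefore expected to give 22000 nM, within the range 8000 nM to 60000 nM, which means an expected step of a 1.4-fold lower number from compound 2 to compound 3 (0.14 log units; within the scatter).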

Compound 3, half-maximal inhibitory concentration: 82400 nM
Compound 3: the middle estimate sits 3.7-fold (0.57 log units) below what was measured; the whole stated range lies below it.
By their numbers in this assay, from the lowest: compound 1; then compound 2; then compound 3.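

In this assay, going by these compounds alone, the halogen on this ring turns out not to be interchangeable: with chloro in place of bromo on the same aromatic carbon, the compounds show a 2.7-fold higher number from compound 2 to compound 3 (0.43 log units; beyond the scatter) as a step that lies beyond the usual scatter, even though only one atom changes. Compounds 1 and 3 carry the same halogen, so they separate the effect of place from that of halogen, which the first comparison could not do; going from 4-chlorophenyl to 3-chlorophenyl gives a 7.6-fold higher number from compound 1 to compound 3 (0.88 log units; beyond the scatter) and shows that where the chlorine sits also matters in this series. Nothing available here accounts for either step, so the reason for them remains unknown.

The compounds shown leave open whether bromine would also differ from chlorine on the 4-position of the ring, since 4-bromophenyl is not among them, and so whether the two changes simply add up. They also leave open how an unsubstituted phenyl ring, a fluoro or methoxy group on that ring, or a longer chain between the sulfur and the ring would compare.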